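A few compounds are considered here, and "the series" means these few. Any claim that something is new, unique, unknown or untested is made for them only; others in the source may bear on it.

Of the compounds shown here, two have so far been measured in a functional assay on CHO cells (Cricetulus griseus) for inhibition, read by MTT assay, with a stated time of 96 h; on this read-out higher numbers stand for weaker inhibition and lower numbers for stronger inhibition. Compound 1, `C=C(C)[C@@H](OC(=O)c1ccc(F)c2ccccc12)C(N)=O`, carries a 1-methylethenyl group and a fluorine on its core; in this assay compound 1 gives > 100000 nM, which is a limit of the assay and not a number. Compound 2, `Cc1ccc(C(=O)O[C@@H](C(N)=O)C2(C)CO2)c2ccccc12`, carries a 2-methyloxiran-2-yl group and a methyl on its core; in this assay compound 2 gives 5000 nM. Compound 2 thus stands as the only real number in the set, the other entry being a limit, as shown by the limit of > 100000 nM in this assay, at which 1 of the 2 values shown sits.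

Compound 3, `C=C(C)[C@@H](OC(=O)c1ccc(C)c2ccccc12)C(N)=O`, has not yet been measured. It keeps the methyl-bearing core of compound 2 and differs from it in one place: 1-methylethenyl in place of 2-methyloxiran-2-yl on a saturated chain carbon bound to a carbonyl carbon and an oxygen next to a carbonyl group. Going by the values given here, no step between two measured compounds shows the effect of this exchange directly. The closest hint comes from compound 1, which also carries the 1-methylethenyl group and in this assay gives only the limit > 100000 nM. On that basis the step of a 10-fold higher number from compound 2 to compound 3 (1.00 log units; beyond the scatter) is expected to run towards weaker inhibition, beyond the usual scatter. Compound 3 is estimated at 50000 nM, within a range from 8000 nM to 100000 nM, with a real chance that this assay reports only a limit.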

Compound 3, half-maximal inhibitory concentration: > 100000 nM
Compound 3 ended at the assay's limit; the forecaster's own chance of this, stated with the estimate: 45%; middle value at least 2.0-fold (0.30 log units) away from the limit.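

In this assay, putting 1-methylethenyl in place of 2-methyloxiran-2-yl on the same methyl-bearing core gives an at least 20-fold higher number from compound 2 to compound 3 (1.30 log units; beyond the scatter), a large step towards weaker inhibition. Going by these compounds alone, this is the first single change in the set whose effect can be read, and it shows that the group at this place, on a saturated chain carbon bound to a carbonyl carbon and an oxygen next to a carbonyl group, can decide whether the compound gives a number at all. Compound 1 could not show this, as it differs from compound 2 in two places, and methyl in place of fluoro on an aromatic carbon, the change from compound 1 to compound 3, cannot be read, as both compounds give a limit of the assay and not a number: the limit of > 100000 nM in this assay, at which 2 of the 3 values shown sit.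

From the compounds shown here alone, the true size of the step stays open, as does how far compound 3 lies past its limit. Also open, going by these compounds, is whether a 1-methylcyclopropyl group, which has a three-membered ring made only of carbon, or an aminomethyl group at this place would keep a measurable number.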